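Hydroxamic acid series: phenyl replacing trifluoromethyl on the cap

The source may hold more compounds than are shown below. What is called first, only, known or untested is meant among the compounds shown, and "the series" means these compounds.

Of the compounds shown here, three have been tested in an assay on isolated protein for inhibition of histone deacetylase 8 (Homo sapiens); on this read-out higher numbers stand for weaker inhibition and lower numbers for stronger inhibition. Compound 1 `O=C(CCCCCCC(=O)c1ccccc1)NO` gives 500 nM in this assay. Compound 2 `COc1ccccc1C(=O)CCCCCCCC(=O)NO` carries a methoxy group on the aryl ketone and one more carbon in the chain, and in this assay compound 2 gives 95 nM. Compound 3 `O=C(CCCCCCCC(=O)c1ccc(C(F)(F)F)cc1)NO`, with a trifluoromethyl on the aryl ketone, gives 45 nM in this assay, the lowest number of the three and thus the strongest inhibitor seen so far; the gap to compound 2 and the larger gap to compound 1 both lie beyond the usual scatter.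

Compound 4 `O=C(CCCCCCCC(=O)c1ccc(-c2ccccc2)cc1)NO` has not yet been measured. It differs from compound 3 in one place: phenyl in place of trifluoromethyl on an aromatic carbon. Among the compounds with values here, no directly comparable pair of measured compounds is available to show what such a change does in this assay, so the expectation rests on compound 3 alone. The step of a 1.3-fold lower number from compound 3 to compound 4 (0.11 log units; within the scatter) is expected to be small, not clearly beyond the scatter, with a slight lean toward a lower number. Compound 4 is therefore estimated to give about 35 nM in this assay, with a likely range from 10 nM to 130 nM.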

Compound 4, half-maximal inhibitory concentration: 5 nM
Compound 4: middle estimate off by 7.0-fold (0.85 log units), on the high side; the measured number lies below the stated range.
By their numbers in this assay, from the lowest: compound 4; then compound 3; then compound 2; then compound 1.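

In this assay, within the data shown here, putting phenyl in place of trifluoromethyl on this aromatic carbon gives a 9.0-fold lower number from compound 3 to compound 4 (0.95 log units; beyond the scatter), the first step that can be read as a change in one place, since the earlier compounds differ from one another in more than one place. The step shows that the group at this position, para to a large group, can strongly influence the read-out, and that a six-membered aromatic ring of carbon only is accepted here with a clear gain rather than a loss. What lies behind the gain cannot be said, as no measurement shown here addresses it.

The compounds shown leave open whether the aromatic ring itself matters or whether a non-aromatic group of similar size, such as cyclohexyl, or a ring containing nitrogen, such as pyridyl, would do the same at this carbon. They also leave open whether an amine or a carboxylic acid on the added phenyl would be accepted, and whether the gain would persist with a shorter or longer chain.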